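This account rests on a few compounds, and the source may have more. Where it says the series, first, only, none or still open, it means among the compounds named here.

Measured so far:
compound 1, `O=C(Nc1ccnnc1)c1cc(N2C[C@H]3COC[C@H]3C2)ccc1OCc1ccccc1`: 50.1 nM
compound 2, `O=C(Nc1cccc(Cl)c1)c1cc(C(F)(F)F)ccc1OCc1ccccc1`: 25.1 nM

Of the compounds shown here, two have been tested in an assay on Sf9 cells for inhibition of Leucine-rich repeat serine/threonine-protein kinase 2 (Homo sapiens), read by TR-FRET, with stated times of 30 min and 2 h; a higher number here means a weaker inhibitor, a lower number a stronger inhibitor. Compound 1 gives 50.1 nM, and compound 2 gives 25.1 nM. Compound 1 has the higher of the two numbers, but its gap to compound 2 is within the scatter of repeated measurements, so the two cannot be told apart on these figures alone.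

Compound 3, `O=C(Nc1ccnnc1)c1cc(N2CCC(F)CC2)ccc1OCc1ccccc1`, has not yet been measured. It differs from compound 1 in one place: a group of 7 heavy atoms (5 carbon, 1 nitrogen, 1 fluorine; one six-membered non-aromatic ring with 1 hetero atom) in place of a group of 8 heavy atoms (6 carbon, 1 nitrogen, 1 oxygen; 2 five-membered non-aromatic rings with 1 hetero atom each), on an aromatic carbon. In words, a group of 7 heavy atoms (5 carbon, 1 nitrogen, 1 fluorine; one six-membered non-aromatic ring with 1 hetero atom) takes the place of a group of 8 heavy atoms (6 carbon, 1 nitrogen, 1 oxygen; 2 five-membered non-aromatic rings with 1 hetero atom each), on an aromatic carbon of the shared core, meta to the (pyridazin-4-yl)carbamoyl group and para to the benzyloxy group.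

Within the data shown here, no measured pair shows what such a swap does here, so the expected step in this assay is small, likely no larger than the scatter, with no firm direction. The step from compound 1 to compound 3 is expected to be a 1.3-fold higher number from compound 1 to compound 3 (0.10 log units; within the scatter). Compound 3 is therefore estimated at 63 nM, within a range of 20 nM to 200 nM.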

Compound 3, half-maximal inhibitory concentration: 39.8 nM
The estimate for compound 3 lay 1.6-fold (0.20 log units) above the measured number; measured number inside the range.
By their numbers in this assay, from the lowest: compounds 2, 3 and 1 (each within the scatter of the next).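

At the place para to the benzyloxy group and meta to the (pyridazin-4-yl)carbamoyl group, putting 4-fluoropiperidin-1-yl in place of the group with 2 five-membered non-aromatic rings gives a 1.3-fold lower number from compound 1 to compound 3 (0.10 log units; within the scatter) in this assay, so this one swap cannot be told apart from no effect at all. Among these compounds, this is the first pair that differs in one place, and it shows that the two groups cannot be separated at this position even though the group that leaves has 2 defined stereocentres and 2 hydrogen-bond acceptors, while the one that enters has 1 hydrogen-bond acceptor. No other measurement bears on this result.

From the compounds shown here alone, whether the fluorine matters remains open, as does what a plain piperidine ring, a morpholine ring or a primary amine at this place would give. Going by these compounds, compound 2 differs from compound 1 and compound 3 in more than one place, so steps to it cannot be read, and the separate contributions of its trifluoromethyl and chlorophenyl groups stay unknown.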